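This account rests on a few compounds, and the source may have more. Where it says the series, first, only, none or still open, it means among the compounds named here.

Measured compounds in an ADME assay on HEL cells (Homo sapiens) for cytotoxicity, with a stated time of 3 days; a higher number here means that more compound is tolerated, a lower number that less compound is tolerated:
compound 1, `Cc1cc(-c2cccs2)cn2c(CSCCc3ccccc3)cnc12`: compound 1 gives 32 ug/mL.
compound 2, `Cc1cc(-c2ccsc2)c2ncc(CSCCc3ccccc3)n2c1`: compound 2 gives a limit of the assay, > 50 ug/mL.
compound 3, `Cc1cc(I)c2ncc(CSCCc3ccccc3)n2c1`: compound 3 gives a limit of the assay, > 50 ug/mL.

For the measured compounds named here, compound 1 stands as the only compound with a number in this assay; the other two values sit at the limit of > 50 ug/mL in this assay, at which 2 of the 3 values shown sit. Going by the values given here, the one measured step between compounds differing in a single place, a step that the two limits leave unreadable from compound 2 to compound 3, cannot be read because both ends are limits.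

Compound 4, `Cc1cc(-c2ccsc2)cn2c(CSCCc3ccccc3)cnc12`, differs from compound 1 by thiophen-3-yl in place of thiophen-2-yl on an aromatic carbon. Among the compounds with values here, no measured step covers this change. Compound 2 also carries thiophen-3-yl, but its core is joined differently and it gives only a limit, so it offers no readable size. Within the data shown here, with no evidence of a step, no change beyond the scatter is expected, a 1.2-fold higher number from compound 1 to compound 4 (0.07 log units; within the scatter). Compound 4 is estimated at 38 ug/mL, between 18 ug/mL and 50 ug/mL.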

Compound 4, half-maximal cytotoxic concentration: > 50 ug/mL
Compound 4: a limit, no number; the forecaster's own chance of this, stated with the estimate: 40%; middle value at least 1.3-fold (0.11 log units) from the limit.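

For the compounds shown here, on this aromatic carbon, two atoms from the ring nitrogen, thiophen-3-yl in place of thiophen-2-yl gives the first step of readable size: an at least 1.5-fold higher number from compound 1 to compound 4 (0.19 log units; that floor lies within the scatter) in this assay on the core of compound 1. Compound 4 gives > 50 ug/mL as a limit of the assay and not a number. The result adds one more compound to the group at the limit: the limit of > 50 ug/mL in this assay, at which 3 of the 4 values shown sit.

As far as these compounds go, whether the true step lies beyond the scatter stays open. From the compounds shown here alone, how an amine, a carboxylic acid or a phenyl ring on this carbon would behave in this assay also stays open.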